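Trifluoromethyl Removal in Two Cores and an Expected Value

The source may report more compounds than this note shows. Statements on the series, on what has been measured and on what is new or still open speak of the compounds shown alone.

Measured compounds in a functional assay on MDA-MB-231 cells (Homo sapiens) for antiproliferative activity, read by sulforhodamine B assay, with a stated time of 72 h; on this read-out lower numbers stand for stronger inhibition and higher numbers for weaker inhibition:
- Compound 1, `FC(F)(F)c1ccc(/C=C\c2cc3ccccc3nc2Cl)cc1`, gives 5360 nM.
- Compound 2, `FC(F)(F)c1ccc(/C=C\c2cc3ccccc3nc2Cl)c(C(F)(F)F)c1`, gives 41800 nM.
- Compound 3, `COc1ccc2nc(Cl)c(/C=C\c3ccc(C(F)(F)F)cc3C(F)(F)F)cc2c1`, reaches only a limit of the assay, > 50000 nM.

Compound 1 and compound 2 share a core; compound 3 and compound 4 share another, and the two cores differ by methoxy in place of hydrogen on an aromatic carbon. Going from compound 2 to compound 3 the step is an at least 1.1-fold higher number from compound 2 to compound 3 (0.07 log units; that floor lies within the scatter), so the methoxy leaves the read-out essentially where it was, as far as a limit allows one to say. This is shown by the limit of > 50000 nM in this assay, at which 1 of the 3 values shown sits.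

The change that matters here is hydrogen in place of trifluoromethyl on an aromatic carbon, which produced a 7.8-fold lower number from compound 2 to compound 1 (0.89 log units; beyond the scatter). Compound 4, `COc1ccc2nc(Cl)c(/C=C\c3ccccc3C(F)(F)F)cc2c1`, is not yet measured and arises from compound 3 by hydrogen in place of trifluoromethyl on an aromatic carbon. This is the same kind of change, but not the same: in the first pair the leaving trifluoromethyl sat ortho to a large group and meta to a trifluoromethyl group, whereas in compound 3 it sits meta to a trifluoromethyl group and para to a large group.

Because compound 3 is known only as a limit, any expectation for compound 4 must rest on that limit and on the direction seen in a 7.8-fold lower number from compound 2 to compound 1 (0.89 log units; beyond the scatter). For compound 4 the expected step in this assay is an at least 1.6-fold lower number from compound 3 to compound 4 (0.22 log units; that floor lies within the scatter), smaller and less certain than the earlier one. Compound 4 is therefore estimated at 30000 nM, with a likely range from 8000 nM to 100000 nM.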

Compound 4, half-maximal inhibitory concentration: 2770 nM
Beside the measured number, compound 4's estimate is 11-fold (1.03 log units) above it; measured number below the stated range.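

In this assay, hydrogen in place of trifluoromethyl on the core carrying the methoxy gave an at least 18-fold lower number from compound 3 to compound 4 (1.25 log units; beyond the scatter), so the number fell on this core as it had on the core of compound 1. The two steps therefore point the same way, but their sizes cannot be ranked: the same change on two cores in this assay, a 7.8-fold lower number (0.89 log units; beyond the scatter) from compound 2 to compound 1 and an at least 18-fold lower number (1.25 log units; beyond the scatter) from compound 3 to compound 4; the limit leaves it open whether they differ. The newer step is only a floor, and the two pairs show a shared direction on these two cores, not a rule for the whole series, since the reading rests on a limit of the assay held by compound 3: the limit of > 50000 nM in this assay, at which 1 of the 4 values shown sits.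

The compounds shown leave open whether replacing the remaining trifluoromethyl group with hydrogen would lower the number further on either core. They also leave open whether a methyl group, a chlorine atom or a nitrile at the place of the departed trifluoromethyl would give a step like that seen with hydrogen, and whether an amine or a carboxylic acid in place of the methoxy would keep the step in the same direction.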